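The source may hold more compounds than are shown below. What is called first, only, known or untested is meant among the compounds shown, and "the series" means these compounds.

Measured in a functional assay on HUVEC cells (Homo sapiens) (a higher number here means that more compound is needed for the effect, a lower number that less compound is needed), all three as limits and not numbers:

Compound 1 `COC1=C(C)C(=O)/C(=C(O)/C=C/c2ccccc2C)C(=O)C1(C)C`: < 4 ug/mL
Compound 2 `COC1=C(C)C(=O)/C(=C(O)/C=C/c2c(C)cccc2C)C(=O)C1(C)C`: < 4 ug/mL
Compound 3 `C=Cc1ccccc1/C=C/C(O)=C1/C(=O)C(C)=C(OC)C(C)(C)C1=O`: < 1.1 ug/mL

Compound 3 is known only as a limit, (the limit of < 1.1 ug/mL in this assay, at which 1 of the 3 values shown sits). Compound 1 and compound 2 are also known only as limits, (the limit of < 4 ug/mL in this assay, at which 2 of the 3 values shown sit). No number is therefore available for any member of the series.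

The next change gives compound 4 `COC1=C(C)C(=O)/C(=C(O)/C=C/c2ccco2)C(=O)C1(C)C`: furan-2-yl in place of 2-vinylphenyl, on a double-bonded chain carbon bound to a double-bonded chain carbon (furan-2-yl in place of 2-vinylphenyl on a double-bonded chain carbon bound to a double-bonded chain carbon). The closest measured change, at that same place, is a step that the two limits leave unreadable from compound 2 to compound 3. Also relevant are a step that the two limits leave unreadable from compound 1 to compound 3 and a step that the two limits leave unreadable from compound 1 to compound 2. Going by the values given here, none of the three gives a size, and no compound carrying furan-2-yl has been measured. With no readable size to carry over, no step beyond the scatter is expected in this assay, and the expected outcome is an at least 1.3-fold higher number from compound 3 to compound 4 (0.13 log units; that floor lies within the scatter). For compound 4 the estimate is 1.5 ug/mL, with an expected range of 0.3 ug/mL to 6 ug/mL.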

Compound 4, concentration for half-maximal effect: < 4 ug/mL
Compound 4: only a limit was reported; the forecaster's own chance of this, stated with the estimate: 50%; the middle value lies beyond the limit too.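

In this assay compound 4 gives < 4 ug/mL, a limit and not a number. Going by these compounds alone, no step to compound 4 from compound 1, compound 2 or compound 3 can be read. The compounds shown leave open whether furan-2-yl, 2-vinylphenyl, 2-methylphenyl and 2,6-dimethylphenyl differ at all in this read-out.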